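Swapping the morpholine amide for a phenylethyl amide

The compounds below may be only part of what the source reports. "The series", "measured", "known", "first", "only" and "open" are said of these compounds alone.

Three compounds share a core built around a diaryl urea bearing a chlorine and a trifluoromethyl group, and differ in the chain that ends in an amide. Compound 1 `C/C(=C\c1ccc(NC(=O)Nc2ccc(Cl)c(C(F)(F)F)c2)cc1)C(=O)NC(C)c1ccccc1` carries a methyl on its double bond and a (1-phenylethyl)amino group on the carbonyl carbon. Compound 2 `CC1CN(C(=O)/C=C/c2ccc(NC(=O)Nc3ccc(Cl)c(C(F)(F)F)c3)cc2)CC(C)O1` has an unsubstituted double bond and a 2,6-dimethylmorpholin-4-yl group. Compound 3 `CNC(=O)CCc1ccc(NC(=O)Nc2ccc(Cl)c(C(F)(F)F)c2)cc1` has a saturated chain and a methylamino group.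

In a functional assay on MX1 cells (Homo sapiens) for inhibition, read by MTT assay, with a stated time of 120 h (on this read-out higher numbers stand for weaker inhibition and lower numbers for stronger inhibition), compound 1 reaches only the limit of > 50000 nM, which is not a number but the edge of what the method reports. In this assay compound 2 gives 12800 nM, the lowest of the two numbers shown, and compound 3 gives 20400 nM, which sits within the usual scatter of that of compound 2.

Compound 4 `CC(NC(=O)/C=C/c1ccc(NC(=O)Nc2ccc(Cl)c(C(F)(F)F)c2)cc1)c1ccccc1` is not yet measured. It differs from compound 2 in one place: (1-phenylethyl)amino in place of 2,6-dimethylmorpholin-4-yl on a carbonyl carbon. Going by the values given here, no measured pair shows this exact change, but compound 1 also carries a (1-phenylethyl)amino group on a carbonyl carbon, and in this assay compound 1 sits at the limit (the limit of > 50000 nM in this assay, at which 1 of the 3 values shown sits). A step toward weaker inhibition is therefore expected, around a 2.3-fold higher number from compound 2 to compound 4 (0.37 log units; beyond the scatter). Compound 4 is expected to give about 30000 nM, within a range from 12000 nM to 80000 nM.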

Compound 4, half-maximal inhibitory concentration: 3130 nM
For compound 4 the middle estimate is 9.6-fold (0.98 log units) above the measured one, and the stated range ends above it.
By their numbers in this assay, from the lowest: compound 4; then compounds 2 and 3 (each within the scatter of the next). At a limit, above all of these: compound 1.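

In this assay, putting (1-phenylethyl)amino in place of 2,6-dimethylmorpholin-4-yl on a carbonyl carbon gives a 4.1-fold lower number from compound 2 to compound 4 (0.61 log units; beyond the scatter), so the group at this place on the amide can move the number beyond the usual scatter. The change also shows that (1-phenylethyl)amino does not by itself go with weak inhibition, since compound 4 carries it and gives the lowest number of the set, on a chain that differs from that of compound 1 only by the methyl on the double bond. Compound 1 still stands at a limit, which is not a number, so the size of the difference made by that methyl cannot be read: the limit of > 50000 nM in this assay, at which 1 of the 4 values shown sits.

The compounds shown do not separate what the aromatic ring, the amide hydrogen and the branching methyl of the new group each contribute, and a plain benzylamino group or an anilino group on the same carbonyl carbon would begin to pull these apart. A piperidin-1-yl group there would ask whether the ring oxygen and the two methyls of the morpholine matter on their own.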